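Removing the hydroxy from a dicyclohexylguanidine sigma ligand

The source may hold more compounds than are shown below. What is called first, only, known or untested is meant among the compounds shown, and "the series" means these compounds.

Compound 1 `Cc1cc(Br)ccc1NC(=N)Nc1ccc(Br)cc1C`: 32 nM
Compound 2 `Cc1cc([N+](=O)[O-])ccc1/N=C(/N)Nc1cccc(O)c1`: 94 nM
Compound 3 `ON=C(NC1CCCCC1)NC1CCCCC1`: 140 nM

In an assay on membranes from brain (Cavia porcellus) for binding affinity to Sigma non-opioid intracellular receptor 1 (Homo sapiens) (on this read-out higher numbers stand for weaker inhibition and lower numbers for stronger inhibition), compound 3 gives 140 nM, the highest of the three numbers. Against compound 2 the gap is within the scatter, so the two cannot be ordered; against compound 1 the gap is beyond the scatter, and compound 1 shows the lower number.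

Compound 4 `N=C(NC1CCCCC1)NC1CCCCC1` differs from compound 3 in one place: hydrogen in place of hydroxy on a double-bonded nitrogen. Going by the values given here, no measured pair shows this change, so its size cannot be read from the data. A modest step toward a lower number is expected, near the edge of the scatter. For compound 4 the expected value in this assay is 70 nM, with a range from 18 nM to 280 nM, an estimated step of a 2.0-fold lower number from compound 3 to compound 4 (0.30 log units; within the scatter).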

Compound 4, half-maximal inhibitory concentration: 48 nM
The estimate for compound 4 lay 1.5-fold (0.16 log units) above the measured number; measured number inside the range.
By their numbers in this assay, from the lowest: compounds 1, 4, 2 and 3 (each within the scatter of the next, the first and the last beyond it).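

Going by these compounds alone, replacing the hydroxy with hydrogen on the double-bonded nitrogen gives a 2.9-fold lower number from compound 3 to compound 4 (0.46 log units; beyond the scatter) in this assay and is the first change here that can be read on its own, as the earlier compounds offered no pair differing in one place. The hydroxy is therefore not needed at this position for binding in this assay, and removing it gives a modest gain. Nothing measured here explains the step.

On these data alone, whether a methyl, a methoxy or an amine in the same place would sit nearer compound 3 or compound 4 stays open. A single pair also cannot show whether the step holds on any other core.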